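This account rests on a few compounds, and the source may have more. Where it says the series, first, only, none or still open, it means among the compounds named here.

In a functional assay on B16-F10 cells (Mus musculus) for cytotoxicity (a higher number here means a weaker inhibitor, a lower number a stronger inhibitor), compound 1 (`O=c1oc2ccccc2c2nc3c(ccc4cc[nH]c43)c(-c3ccc(Br)cc3)c12`) gives 70700 nM, and compound 2 (`O=c1oc2ccccc2c2nc3c(ccc4cc[nH]c43)c(-c3c(Cl)cccc3Cl)c12`), which carries a 2,6-dichlorophenyl group, gives 70700 nM. Within the data shown here, compound 2 therefore stands level with compound 1, the only other compound measured so far. Compound 3 (`O=c1oc2ccccc2c2nc3c(ccc4cc[nH]c43)c(-c3ccc(Cl)cc3Cl)c12`) has 2,4-dichlorophenyl in place of 2,6-dichlorophenyl on an aromatic carbon, opposite the ring nitrogen: 2,4-dichlorophenyl in place of 2,6-dichlorophenyl on an aromatic carbon. Among the measured compounds shown here, only one measured step bears on this change, the exchange of the aryl group at that carbon, and it shows no change at the digits printed from compound 1 to compound 2 (within the scatter). For the measured compounds named here, that single step is slim evidence, and no measured compound yet carries the 2,4-dichlorophenyl group. On the strength of it, no step beyond the scatter is expected in this assay. The expected step is a 1.0-fold lower number from compound 2 to compound 3 (0.00 log units; within the scatter). Compound 3 is estimated at 70000 nM, with an expected range of 35000 nM to 120000 nM.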

Compound 3, half-maximal inhibitory concentration: 70700 nM
Beside the measured number, compound 3's estimate is 1.0-fold (0.00 log units) below it; the measured number falls inside the stated range.
By their numbers in this assay, from the lowest: compounds 1, 2 and 3 (each within the scatter of the next).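

In this assay, among these compounds, the result tests for the first time how the two chlorines are arranged on the phenyl ring: compound 2 and compound 3 have the same atoms, joined differently, yet the record reads no change at the digits printed from compound 2 to compound 3 (within the scatter) for this exchange. A second exchange at this aromatic carbon, opposite the ring nitrogen, reads no change at the digits printed from compound 1 to compound 3 (within the scatter) as well, so the 4-bromophenyl, 2,6-dichlorophenyl and 2,4-dichlorophenyl groups all stand level in these three compounds. Nothing given here accounts for this lack of difference.

Going by these compounds, all three groups are phenyl rings bearing halogens, so it remains open whether an amine or a carboxylic acid on that ring would move the number. On these data alone, the unsubstituted phenyl group and a methoxy-bearing phenyl group at this carbon are equally open.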